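Aryl Swaps on a Shared Core Against Breast Cancer Cells

This account rests on a few compounds, and the source may have more. Where it says the series, first, only, none or still open, it means among the compounds named here.

Compound 1 `COc1ccc(-c2cc(CO[C@H]3CC(=O)[C@@H]4OC[C@H]3O4)on2)cc1`: 21900 nM
Compound 2 `O=C1C[C@H](OCc2cc(/C=C/c3ccccc3)no2)[C@H]2CO[C@@H]1O2`: 22900 nM

In a functional assay on MDA-MB-231 cells (Homo sapiens) for cytotoxicity, read by MTT assay, with a stated time of 48 h (a lower number here means a stronger inhibitor, a higher number a weaker inhibitor), compound 2 gives 22900 nM. Compound 1 gives 21900 nM, and the step of a 1.0-fold higher number from compound 1 to compound 2 (0.02 log units; within the scatter) lies within the scatter, so the two numbers cannot be ordered. Compound 3 `O=C1C[C@H](OCc2cc(-c3ccc(Cl)cc3)no2)[C@H]2CO[C@@H]1O2` differs from compound 2 by 4-chlorophenyl in place of 2-phenylethenyl on an aromatic carbon. Going by the values given here, the only measured step that bears on this, a 1.0-fold higher number from compound 1 to compound 2 (0.02 log units; within the scatter), also exchanged the group on that aromatic carbon and left the number essentially unchanged. The expected step of a 1.0-fold lower number from compound 2 to compound 3 (0.02 log units; within the scatter) is therefore none beyond the scatter. Compound 3 is estimated at 22000 nM, with a range of 9000 nM to 55000 nM.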

Compound 3, half-maximal inhibitory concentration: 17900 nM
For compound 3 the middle estimate is 1.2-fold (0.09 log units) above the measured one; low and high end bracket the measured number.
By their numbers in this assay, from the lowest: compounds 3, 1 and 2 (each within the scatter of the next).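

In this assay, the aromatic carbon next to the ring nitrogen now carries a third group, 4-chlorophenyl, and the number again stays within the scatter: a 1.3-fold lower number from compound 2 to compound 3 (0.11 log units; within the scatter). Chloro in place of methoxy on an aromatic carbon also gives no readable change, with a 1.2-fold lower number from compound 1 to compound 3 (0.09 log units; within the scatter). Nothing measured here offers an explanation for these results. The compounds shown leave open whether an amine or a carboxylic acid on that aromatic ring would move the number beyond the scatter. They also leave open whether a short alkyl chain at this position would do so.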